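A few compounds are considered here, and "the series" means these few. Any claim that something is new, unique, unknown or untested is made for them only; others in the source may bear on it.

- compound 1 `O=C(CCCCCCc1nc(-c2ccc(C(F)(F)F)cc2)no1)NO`: 14000 nM
- compound 2 `O=C(CCCCCCc1nc(-c2ccccc2)no1)C(F)(F)F`: 7680 nM

In a functional assay on A549 cells (Homo sapiens) for antiproliferative activity, read by MTT assay, with a stated time of 72 h (on this read-out higher numbers stand for weaker inhibition and lower numbers for stronger inhibition), compound 2 gives 7680 nM and compound 1 gives 14000 nM. These two numbers lie within the usual scatter, so compound 2 stands level with compound 1. Compound 3 `O=C(CCCCCCc1nc(-c2ccc([N+](=O)[O-])cc2)no1)C(F)(F)F` differs from compound 2 by one change, nitro in place of hydrogen on an aromatic carbon, para to a large group. For the measured compounds named here, no measured pair shows this change, so no step beyond the scatter is expected in this assay, and no direction is favoured. The expected change is a 1.0-fold lower number from compound 2 to compound 3 (0.01 log units; within the scatter). The estimated value for compound 3 is 7500 nM, with an expected range from 2800 nM to 20000 nM.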

Compound 3, half-maximal inhibitory concentration: > 100000 nM
Compound 3: only a limit was reported; the forecaster's own chance of this, stated with the estimate: 5%; middle value at least 13-fold (1.12 log units) from the limit.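

In this assay, for the compounds shown here, the earlier compounds gave no sign that this ring position mattered, but nitro in place of hydrogen on an aromatic carbon, para to a large group, gives an at least 13-fold higher number from compound 2 to compound 3 (1.11 log units; beyond the scatter). Compound 3 reads > 100000 nM, which is a limit of the assay and not a number. The true size of the step therefore stays unknown, and the printed size is only a minimum: the limit of > 100000 nM in this assay, at which 1 of the 3 values shown sits.

On these data alone, whether an amine or a methoxy group at the same position would cost as much remains open. With a single substituted example on this core, the compounds shown cannot say whether the loss is specific to nitro.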